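The source may hold more compounds than are shown below. What is called first, only, known or untested is meant among the compounds shown, and "the series" means these compounds.

Compound 2 `NC(=O)c1cccc(NC(=O)c2cnc3ccccc3c2)c1` in a physicochemical assay for solubility (on this read-out higher numbers stand for higher solubility and lower numbers for lower solubility), gives < 5 ug/mL, which is a limit of the assay and not a number. Its reading is the limit of < 5 ug/mL in this assay, at which 1 of the 2 values shown sits. Compound 1 `NC(=O)c1ccccc1NC(=O)c1cnc2ccccc2c1` in this assay gives 5 ug/mL. Among the compounds with values here, no step between compound 1 and compound 2 is given, so their two values show only that one sits at a number and the other at a limit, with nothing to say about their order. Compound 3 `O=C(Nc1ccccc1)c1cnc2ccccc2c1` has not yet been measured in this assay. It differs from compound 2 by hydrogen in place of carbamoyl on an aromatic carbon. Within the data shown here, with no measured step to lean on, the step expected for this change is small, at most on the edge of the scatter, and if anything downward rather than upward. Compound 3 is expected to give 3 ug/mL, within 1 ug/mL to 10 ug/mL, which means an expected step that the limit leaves unreadable from compound 2 to compound 3.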

Compound 3, solubility: 5 ug/mL
Estimate against measurement, compound 3: 1.7-fold (0.22 log units) below; the range from low to high includes it.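

In this assay the series now holds a readable step for hydrogen in place of carbamoyl on an aromatic carbon, the step of no change at the digits printed from compound 1 to compound 3 (within the scatter), and this pair gives no sign that the carbamoyl of compound 1 moves the reading. In compound 2, carbamoyl sits on the aromatic carbon meta to a large group, and compound 2 reads < 5 ug/mL, which is a limit of the assay and not a number. The size of the step at this position therefore cannot be read, and the comparison stops at: the limit of < 5 ug/mL in this assay, at which 1 of the 3 values shown sits.

As far as these compounds go, how far carbamoyl at this position shifts the reading stays open: the data give only a number no lower from compound 2 to compound 3 (the limit leaves the size open). Also open, from the compounds shown here alone, is whether an amine, a carboxylic acid or a longer chain on this aromatic carbon would give a reading different from that of compound 3.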